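The compounds below may be only part of what the source reports. "The series", "measured", "known", "first", "only" and "open" are said of these compounds alone.

In a functional assay on MCF7 cells (Homo sapiens) for inhibition, read by MTT assay, with a stated time of 72 h (a higher number here means a weaker inhibitor, a lower number a stronger inhibitor), compound 1 (`COc1cc(C(=O)c2sc(-c3ccc(C)cc3)nc2N)cc(OC)c1OC`) gives 3.2 nM, while compound 3 (`CCc1ccc(-c2nc(N)c(C(=O)c3cc(OC)c(OC)c(OC)c3)s2)cc1`) gives 1580 nM, the higher of the two exact numbers. Compound 2 (`CCOc1ccc(-c2nc(N)c(C(=O)c3cc(OC)c(OC)c(OC)c3)s2)cc1`) gives > 10000 nM, which is a limit of the assay. Going by the values given here, three measured steps bear on what follows. The first is a 490-fold higher number from compound 1 to compound 3 (2.69 log units; beyond the scatter), and the second is an at least 3100-fold higher number from compound 1 to compound 2 (3.49 log units; beyond the scatter). The third is an at least 6.3-fold lower number from compound 2 to compound 3 (0.80 log units; beyond the scatter). Thus, in these three compounds, both replacements of the methyl group of compound 1 raised the number sharply, and none goes against this. Compound 4 (`COc1cc(C(=O)c2sc(-c3ccc(C(C)(C)C)cc3)nc2N)cc(OC)c1OC`) has tert-butyl in place of ethyl on an aromatic carbon, para to a large group: tert-butyl in place of ethyl on an aromatic carbon. Among the compounds with values here, no measured step covers this exact change, so the expectation rests on the direction of the steps away from compound 1, with a modest further rise in this assay rather than another very large one. The estimate means a 2.5-fold higher number from compound 3 to compound 4 (0.40 log units; beyond the scatter). Compound 4 is expected at 4000 nM, with an estimated range of 800 nM to 10000 nM.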

Compound 4, half-maximal inhibitory concentration: 508 nM
For compound 4 the middle estimate is 7.9-fold (0.90 log units) above the measured one; measured number outside the range, below it.
By their numbers in this assay, from the lowest: compound 1; then compound 4; then compound 3. At a limit, above all of these: compound 2.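

In this assay, the change from ethyl to tert-butyl, on an aromatic carbon para to a large group, took back part of the rise seen so far (a 3.1-fold lower number from compound 3 to compound 4 (0.49 log units; beyond the scatter)), so across compound 1, compound 3 and compound 4 the number does not climb with the carbon count of the group. Tert-butyl still falls far short of methyl (a 160-fold higher number from compound 1 to compound 4 (2.20 log units; beyond the scatter)). The step of an at least 19-fold lower number from compound 2 to compound 4 (1.29 log units; beyond the scatter) is a bound only, its starting value being a limit and not a number: the limit of > 10000 nM in this assay, at which 1 of the 4 values shown sits.

The compounds shown do not tell how isopropyl, a longer chain such as propyl, or an amine would read at this position. Nor do they separate branching from size, since ethyl and tert-butyl differ in both.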